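The compounds below may be only part of what the source reports. "The series", "measured", "known", "first", "only" and "open" are said of these compounds alone.

Measured so far:
Compound 1, `N/C(=N\NC(=S)N1CCOCC1)c1ccccn1`: 29.2%
Compound 2, `Cc1cccc(/C(N)=N/NC(=S)N2CCCC2)n1`: 21%

Both were tested in a functional assay on A-431 cells (Homo sapiens) for cytotoxicity, read by MTT assay, with a stated time of 72 h, tested at 1 uM; on this read-out higher numbers stand for more inhibition of growth at the one concentration tested and lower numbers for less inhibition of growth. The number for compound 2 lies within the usual scatter of the number for compound 1, so the two cannot be told apart on this read-out. Compound 3, `N/C(=N\NC(=S)N1CCCC1)c1ccccn1`, is not yet measured; it differs from compound 2 by hydrogen in place of methyl on an aromatic carbon. For the measured compounds named here, no measured pair shows what this single change does on its own, so no shift beyond the scatter is expected in either direction. The estimate for compound 3 is 25%, with a range from 10% to 40%. The step this expectation implies, a number 4 percentage points higher from compound 2 to compound 3 (within the scatter), stays within the scatter.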

Compound 3, percent growth inhibition at one concentration: 39.8%
The estimate for compound 3 lay 14.8 percentage points below the measured number; measured number inside the range.
By their numbers in this assay, from the lowest: compounds 2 and 1 (each within the scatter of the next); then compound 3.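

In this assay, the methyl on the aromatic carbon next to the ring nitrogen turns out to matter: hydrogen in its place gives a number 18.8 percentage points higher from compound 2 to compound 3 (beyond the scatter). The group on the thiocarbonyl carbon matters too, as pyrrolidin-1-yl in place of morpholin-4-yl gives a number 10.6 percentage points higher from compound 1 to compound 3 (beyond the scatter). Nothing available explains why either change has this effect.

As far as these compounds go, whether an amine or a chlorine atom at the methyl position would raise or lower growth inhibition remains open. So does the effect of piperidin-1-yl on the thiocarbonyl carbon.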